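Piperidine-linked benzoxazole ethers: two measured, one open

This account rests on a few compounds, and the source may have more. Where it says the series, first, only, none or still open, it means among the compounds named here.

Compound 1 `Clc1ccc(Oc2ccc3nc(-c4ccc(OC5CCNCC5)cc4)oc3c2)cc1` gives 20.6% in an assay on isolated protein for inhibition of advanced glycosylation end product-specific receptor (Homo sapiens), read by FRET, with stated times of 30 min and 1 h, tested at 4 uM; a lower number here means less inhibition, a higher number more inhibition at the concentration tested (going by the name of the read-out). Compound 2 `Clc1ccc(Oc2ccc3nc(-c4ccc(OCC5CCNCC5)cc4)oc3c2)cc1` shows no single number in this assay; it is recorded as "not active" (no number reported), so its standing can only be read as below the level of compound 1. Compound 3 `CN1CCC(Oc2ccc(-c3nc4ccc(Oc5ccc(Cl)cc5)cc4o3)cc2)CC1` is not yet measured. The change from compound 2 is 1-methylpiperidin-4-yl in place of (piperidin-4-yl)methyl on an oxygen on an aromatic ring. Compound 3 carries the same ring attachment as compound 1, so the step from compound 2 to compound 3 is expected to be a modest rise in this assay, beyond the scatter at most by a little. For compound 3 the estimate in this assay is 18%, with a range of 0% to 38%.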

Compound 3, a percentage reported as inhibition, at one concentration (the size of the read-out at that concentration, not a potency): 19.5%
Compound 3: the middle estimate sits 1.5 percentage points below what was measured; low and high end bracket the measured number.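

In this assay, methyl in place of hydrogen on the amine nitrogen in the ring gives a number 1.1 percentage points lower from compound 1 to compound 3 (within the scatter), so the hydrogen on that nitrogen is not required for the inhibition seen here. Compound 2 is recorded as not active, whereas its same-atom counterpart compound 3 gives 19.5%, and the two ring-on-oxygen compounds, compound 1 and compound 3, both have numbers. No measurement at hand accounts for this result. Still open, on these data alone, is whether an ethyl or benzyl group on the ring nitrogen, or an acetyl group there, keeps this reading. Also open, as far as these compounds go, is whether methyl on the ring nitrogen of compound 2 yields a number.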